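Fewer fluorines on the ethenyl phenyl: compound 3 to compound 4

The compounds below may be only part of what the source reports. "The series", "measured", "known", "first", "only" and "open" are said of these compounds alone.

In an assay on isolated protein with Bile acid receptor (Homo sapiens) as the target (on this read-out lower numbers stand for an effect already at smaller amounts and higher numbers for an effect only at larger amounts of compound), compound 1 `COC(=O)/C=C/c1cccc(N(Cc2ccc(/C=C/c3c(Cl)cccc3Cl)cc2)C(=O)C(C)C)c1` gives 195 nM, compound 2 `COC(=O)/C=C/c1cccc(N(Cc2ccc(/C=C/c3cc(C(F)(F)F)cc(C(F)(F)F)c3)cc2)C(=O)C(C)C)c1` gives 1950 nM and compound 3 `COC(=O)/C=C/c1cccc(N(Cc2ccc(/C=C/c3c(F)cccc3F)cc2)C(=O)C(C)C)c1` gives 108 nM. Compound 3 carries the lowest of the three numbers, but its gap to compound 1 lies within the scatter, so no order between the two can be claimed; only compound 2 stands clearly apart. Among the measured compounds shown here, the one single-point step so far, a 1.8-fold lower number from compound 1 to compound 3 (0.26 log units; within the scatter), exchanges one pair of halogens for another at the same place and moves nothing beyond the scatter.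

Compound 4 `COC(=O)/C=C/c1cccc(N(Cc2ccc(/C=C/c3cccc(F)c3)cc2)C(=O)C(C)C)c1` differs from compound 3 by 3-fluorophenyl in place of 2,6-difluorophenyl on a double-bonded chain carbon bound to a double-bonded chain carbon. For the measured compounds named here, no measured step removes a halogen or shifts it along the ring; the swap in a 1.8-fold lower number from compound 1 to compound 3 (0.26 log units; within the scatter) kept the substitution pattern. Compound 2, whose ring bears two trifluoromethyls elsewhere, shows a markedly higher number than compound 3, but its change is not a single step. The expectation for compound 4 in this assay is therefore a modest rise, a 2.3-fold higher number from compound 3 to compound 4 (0.36 log units; beyond the scatter), with wide uncertainty. Compound 4 is estimated at 250 nM, range 80 nM to 800 nM.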

Compound 4, half-maximal effective concentration: 71 nM
For compound 4 the middle estimate is 3.5-fold (0.55 log units) above the measured one; the whole stated range lies above it.
By their numbers in this assay, from the lowest: compounds 4, 3 and 1 (each within the scatter of the next, the first and the last beyond it); then compound 2.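

In this assay, among the compounds shown here, the step of a 1.5-fold lower number from compound 3 to compound 4 (0.18 log units; within the scatter) is the first at this place that alters both the number of fluorines and the substitution pattern, and it shows no change that can be claimed. Measured against 2,6-dichlorophenyl, the step of a 2.7-fold lower number from compound 1 to compound 4 (0.44 log units; beyond the scatter) clears the scatter, whereas the step of a 1.8-fold lower number from compound 1 to compound 3 (0.26 log units; within the scatter) does not. The 2,6-difluorophenyl pattern is therefore not required to keep the number at this level, and a single fluorine in 3-fluorophenyl serves as well within the scatter.

Nothing shown explains these differences. On these data alone, the swap from 2,6-difluorophenyl to 3-fluorophenyl changes fluorine count and pattern together, leaving their separate contributions unresolved, and plain phenyl, 3-chlorophenyl or a phenyl bearing an amine at this place remain open.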